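Methoxycarbonyl in place of cyano on compound 3

This account rests on a few compounds, and the source may have more. Where it says the series, first, only, none or still open, it means among the compounds named here.

Measured in an assay for inhibition of Indoleamine 2,3-dioxygenase 1 (Homo sapiens), with stated times of 10 min and 60 min, tested at 100 uM; a lower number here means a weaker effect, a higher number a stronger effect of the compound at the concentration tested:
- compound 1, `O=[N+]([O-])c1cccc(CNc2cc(Br)cc3[nH]ncc23)c1`: 95%
- compound 2, `O=[N+]([O-])c1ccccc1CNc1cccc2[nH]ncc12`: 65%
- compound 3, `N#Cc1cc(NCc2ccccc2[N+](=O)[O-])c2cn[nH]c2c1`: 17%

Compound 3 stands lowest of the three numbers: its nearest neighbour is compound 2, beyond the scatter above it, and compound 1 lies furthest above. Among the measured compounds shown here, the one measured step that touches the same site is a number 48 percentage points lower from compound 2 to compound 3 (beyond the scatter), a large drop.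

Compound 4, `COC(=O)c1cc(NCc2ccccc2[N+](=O)[O-])c2cn[nH]c2c1`, differs from compound 3 by methoxycarbonyl in place of cyano on an aromatic carbon. For the measured compounds named here, no measured step exchanges one group for another at that carbon; the only guide is that a group there, in compound 3, coincides with a much lower number than the bare ring of compound 2. Compound 4 is therefore expected to stay low in this assay, with a step of a number 2 percentage points lower from compound 3 to compound 4 (within the scatter) that need not exceed the scatter. The estimate for compound 4 is 15%, in the range 0% to 40%.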

Compound 4, a percentage reported as inhibition, at one concentration (the size of the read-out at that concentration, not a potency): 47%
The estimate for compound 4 lay 32 percentage points below the measured number; measured number above the stated range.
By their numbers in this assay, from the lowest: compound 3; then compound 4; then compound 2; then compound 1.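

In this assay, the read-out at this aromatic carbon depends on which group sits there, not merely on whether the hydrogen is replaced: methoxycarbonyl in place of cyano gives a number 30 percentage points higher from compound 3 to compound 4 (beyond the scatter). Methoxycarbonyl still does not restore the level of the unsubstituted ring, with a number 18 percentage points lower from compound 2 to compound 4 (beyond the scatter), so both groups read below hydrogen here, by different margins. Nothing available explains the difference between the two groups.

As far as these compounds go, whether the recovery is specific to methoxycarbonyl remains open. A carboxylic acid or an amide at this carbon would test that.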